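Dimethoxyphenyl variant of a tetrazole isoxazoline series

The source may hold more compounds than are shown below. What is called first, only, known or untested is meant among the compounds shown, and "the series" means these compounds.

Compound 1 `COc1cc(-n2nnnc2-c2ccc(OCC3CC(c4ccc(C(F)(F)F)cc4)=NO3)c(N)c2)cc(OC)c1OC` is the reference point. In a functional assay on MDA-MB-231 cells (Homo sapiens) for cytotoxicity, read by MTT assay, with a stated time of 48 h (a lower number here means a stronger inhibitor, a higher number a weaker inhibitor), compound 1 gives 1750 nM, the lowest of the three numbers in this assay. Compound 2 `COc1ccc(C2=NOC(COc3ccc(-c4nnnn4-c4cc(OC)c(OC)c(OC)c4)cc3N)C2)cc1O` gives 3380 nM and compound 3 `COc1cc(C2=NOC(COc3ccc(-c4nnnn4-c4cc(OC)c(OC)c(OC)c4)cc3N)C2)ccc1O` gives 3620 nM; the steps are a 1.9-fold higher number from compound 1 to compound 2 (0.29 log units; within the scatter) and a 2.1-fold higher number from compound 1 to compound 3 (0.32 log units; beyond the scatter), while between the two hydroxy-methoxy analogues the step is a 1.1-fold higher number from compound 2 to compound 3 (0.03 log units; within the scatter).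

Compound 4 `COc1ccc(C2=NOC(COc3ccc(-c4nnnn4-c4cc(OC)c(OC)c(OC)c4)cc3N)C2)cc1OC` is the next member. It differs from compound 1 as follows: 3,4-dimethoxyphenyl in place of 4-(trifluoromethyl)phenyl on a carbon with a double bond to nitrogen. Both measured steps from compound 1 replace the same 4-(trifluoromethyl)phenyl on a carbon with a double bond to nitrogen by an oxygen-bearing phenyl, and both gave a small rise in the number, one within the scatter and one modestly beyond it. Compound 4 is therefore expected to sit near compound 2 and compound 3, with an expected step of a 1.9-fold higher number from compound 1 to compound 4 (0.29 log units; within the scatter). Compound 4 is estimated at 3400 nM, with a range from 1700 nM to 7000 nM.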

Compound 4, half-maximal inhibitory concentration: 3570 nM
Estimate against measurement, compound 4: 1.1-fold (0.02 log units) below; the measured number falls inside the stated range.
By their numbers in this assay, from the lowest: compounds 1, 2, 4 and 3 (each within the scatter of the next, the first and the last beyond it).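

In this assay, the 3,4-dimethoxyphenyl group, which carries no hydrogen-bond donors, gives a 2.0-fold higher number from compound 1 to compound 4 (0.31 log units; beyond the scatter), so at this position a step of this size away from 4-(trifluoromethyl)phenyl does not depend on a free hydroxy group on the entering ring. Placing methyl on the hydroxy oxygen of either earlier analogue stays within the scatter, with a 1.0-fold lower number from compound 3 to compound 4 (0.01 log units; within the scatter) and a 1.1-fold higher number from compound 2 to compound 4 (0.02 log units; within the scatter), so compounds 2, 3 and 4 cannot be told apart here, whichever oxygen is free or capped. No measurement is available that would explain these numbers.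

The compounds shown leave open whether the modest rise follows the loss of trifluoromethyl or the arrival of the oxygen substituents. An unsubstituted phenyl, or a phenyl bearing an amine or a nitrile, would help to separate these two readings.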